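The compounds below may be only part of what the source reports. "The series", "measured", "known", "first", "only" and "open" are said of these compounds alone.

Measured compounds in the series:

compound 1, `Cc1ccccc1C#Cc1ccc(C(=O)N[C@H](C)C(C)(C)O)nc1` — 59.9%
compound 2, `C[C@@H](NC(=O)c1ccc(C#CC2CCCC2)cn1)C(C)(C)O` — 63.7%
compound 3, `CC(C)[C@@H](C)NC(=O)c1ccc(C#Cc2cccc(F)c2)cn1` — 69.3%

In a functional assay on HEK293 cells for positive allosteric modulation of metabotropic glutamate receptor 5 (Rattus norvegicus), read by fluorescence and calcium flux (a higher number here means a larger maximal response, a lower number a smaller maximal response), compound 3 gives 69.3%, the highest of the three numbers, but its gaps to compound 2 and to compound 1 both lie within the scatter, so the three measured compounds cannot be ranked against one another. For the measured compounds named here, the one single-point step measured so far, a number 3.8 percentage points higher from compound 1 to compound 2 (within the scatter), concerns the group on the triple-bonded carbon, not the amide-type nitrogen, and it is itself within the scatter.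

Compound 4, `CC(C)(CO)NC(=O)c1ccc(C#Cc2cccc(F)c2)cn1`, is the next compound to be measured. Compared with compound 3 it carries 1-(hydroxymethyl)-1-methylethyl in place of 1,2-dimethylpropyl on an amide-type nitrogen. Going by the values given here, no measured step in this assay isolates a change on the amide-type nitrogen, so there is no direct precedent for this change. What the numbers do show is that compound 1, compound 2 and compound 3, which differ from one another both on the triple-bonded carbon and on the amide-type nitrogen, all sit within the scatter of each other in this assay. On that basis the expected step of a number 5.3 percentage points lower from compound 3 to compound 4 (within the scatter) is no change beyond the scatter. Compound 4 is therefore estimated at 64%, with a range from 50% to 78%.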

Compound 4, largest response reached (reported as efficacy), in percent of the reference or control that the assay uses: 60.9%
Beside the measured number, compound 4's estimate is 3.1 percentage points above it; the measured number falls inside the stated range.
By their numbers in this assay, from the lowest: compounds 1, 4, 2 and 3 (each within the scatter of the next).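

In this assay, for the compounds shown here, the amide-type nitrogen now has its first single-point reading, a number 8.4 percentage points lower from compound 3 to compound 4 (within the scatter), whereas the only earlier step concerned the group on the triple-bonded carbon. Exchanging 1,2-dimethylpropyl for 1-(hydroxymethyl)-1-methylethyl keeps the heavy-atom count at 5, puts one oxygen into the group, brings in a hydrogen-bond donor and a hydrogen-bond acceptor, and removes the defined stereocentre, yet the maximal responses of this pair cannot be told apart, so in this one pair the position takes either group without a change beyond the scatter. No measurement available here bears on why this pair reads as it does.

Going by these compounds, whether a longer chain, an amine or a carboxylic acid on the amide-type nitrogen would shift the maximal response beyond the scatter remains open. Also open, on these data alone, is whether the same exchange on the amide-type nitrogen would read the same way with cyclopentyl or 2-methylphenyl on the triple-bonded carbon.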